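Pyrazinyl in Place of Hydroxyphenyl on a Weak Blocker

A few compounds are considered here, and "the series" means these few. Any claim that something is new, unique, unknown or untested is made for them only; others in the source may bear on it.

Going by the values given here, compound 1 `CC(O)(C(=O)Nc1ccc(S(=O)(=O)c2cccc(O)c2)cc1)C(F)(F)F` is one of two compounds measured here. Among the compounds with values here, in a functional assay (Cavia porcellus) with sulfonylurea receptors; K-ATP channels (Homo sapiens) as the target (a lower number here means a stronger inhibitor, a higher number a weaker inhibitor), compound 1 gives 18000 nM, and this is the only plain number among the values shown. The second compound, compound 2 `CC(O)(C(=O)Nc1ccc(C(=O)c2ccccc2)cc1Br)C(F)(F)F`, does not give a number: in this assay compound 2 reaches only the limit of the assay, > 30000 nM. Thus (the limit of > 30000 nM in this assay, at which 1 of the 2 values shown sits). Compound 3 `CC(O)(C(=O)Nc1ccc(S(=O)(=O)c2cnccn2)cc1)C(F)(F)F` differs from compound 1 in one place: pyrazin-2-yl in place of 3-hydroxyphenyl on a sulfonyl sulfur. Within the data shown here, no measured pair shows the effect of such a change, so the step from compound 1 to compound 3 in this assay cannot be read from the data; a step within the scatter or a modest weakening appears most likely, with a real chance that only a limit is reported. Compound 3 is expected to give about 25000 nM in this assay, within an estimated range from 8000 nM to 60000 nM. The step this estimate implies is a 1.4-fold higher number from compound 1 to compound 3 (0.14 log units; within the scatter).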

Compound 3, half-maximal inhibitory concentration: 12000 nM
The estimate for compound 3 lay 2.1-fold (0.32 log units) above the measured number; the measured number falls inside the stated range.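

In this assay, going by these compounds alone, the exchange of 3-hydroxyphenyl for pyrazin-2-yl on the sulfonyl sulfur gives a 1.5-fold lower number from compound 1 to compound 3 (0.18 log units; within the scatter), the first step that can be read at this position. The 3-hydroxyphenyl group and its hydrogen-bond donor can therefore leave this position with no change beyond the scatter, and compound 3 still gives a plain number. Steps to compound 2 cannot be read, since it differs from the others in more than one place, and its value is a limit of the assay, not a number: the limit of > 30000 nM in this assay, at which 1 of the 3 values shown sits.

Going by these compounds, it remains open whether an amine or a carboxylic acid on the ring at this position would move the number beyond the scatter. A single step also cannot separate any effect of the hydroxyl from that of the ring nitrogens, which a pyridin-2-yl group would begin to address.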